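Carbamate Selenocyanates: Removing a Chloro Group

This account rests on a few compounds, and the source may have more. Where it says the series, first, only, none or still open, it means among the compounds named here.

Measured compounds:
compound 1 `CCCOC(=O)Nc1ccc([Se]C#N)cc1` — 46300 nM
compound 2 `N#C[Se]c1ccc(NC(=O)Oc2ccc(Cl)cc2)cc1` — 38000 nM

In an ADME assay on BEAS-2B cells (Homo sapiens) for cytotoxicity, read by MTT assay, with a stated time of 72 h (on this read-out lower numbers stand for stronger inhibition of growth and higher numbers for weaker inhibition of growth), compound 1 gives 46300 nM and compound 2 gives 38000 nM; the two numbers lie within the scatter of each other, so neither can be set apart. Compound 3 `N#C[Se]c1ccc(NC(=O)Oc2ccccc2)cc1` differs from compound 2 by hydrogen in place of chloro on an aromatic carbon. For the measured compounds named here, no measured pair shows what such a change does here, so the account expects no step beyond the scatter in this assay, in either direction. For compound 3 the estimate is 40000 nM in this assay, with a range from 18000 nM to 90000 nM, which means an expected step of a 1.1-fold higher number from compound 2 to compound 3 (0.02 log units; within the scatter).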

Compound 3, concentration for total growth inhibition: 38200 nM
Beside the measured number, compound 3's estimate is 1.0-fold (0.02 log units) above it; the range from low to high includes it.
By their numbers in this assay, from the lowest: compounds 2, 3 and 1 (each within the scatter of the next).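

In this assay, for the compounds shown here, hydrogen in place of chloro on an aromatic carbon gives a 1.0-fold higher number from compound 2 to compound 3 (0.00 log units; within the scatter) and so gives the first single-place comparison at this position, with no step beyond the scatter. Phenyl in place of propyl on an oxygen next to a carbonyl group gives a 1.2-fold lower number from compound 1 to compound 3 (0.08 log units; within the scatter) and so also stays within the scatter. Nothing available here offers an explanation for either result. Still open, as far as these compounds go, is whether an amine or a carboxylic acid on that aromatic carbon would move the number beyond the scatter. The same question stands for a longer chain in place of propyl on the oxygen.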